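This account rests on a few compounds, and the source may have more. Where it says the series, first, only, none or still open, it means among the compounds named here.

Of the compounds shown here, three have been read in a functional assay on U-87MG ATCC cells for antiproliferative activity against U-87 MG (Homo sapiens), read by MTT assay, with a stated time of 48 h, tested at 10 uM; a lower number here means a stronger effect, a higher number a weaker effect of the compound at the concentration tested. Compound 1, `COc1ccc(-c2nc(C)c(C(=O)CSc3nc(N)c(C#N)c(-c4ccc(Cl)cc4)n3)s2)cc1`, gives 44%. Compound 3, `COc1ccc(-c2nc(C)c(C(=O)CSc3nc(-c4cccc(OC)c4)c(C#N)c(=O)[nH]3)s2)cc1`, gives 66.7%. Compound 2, `Cc1nc(-c2ccc(Cl)cc2)sc1C(=O)CSc1nc(-c2ccccc2)c(C#N)c(=O)[nH]1`, gives 83.1%, the highest of the three numbers: the number for compound 3 sits lower by a margin beyond the scatter, and the number for compound 1 sits lower still, also beyond the scatter, so compound 2 shows the weakest effect of the three at the concentration tested.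

Compound 4, `Cc1nc(-c2ccc(Cl)cc2)sc1C(=O)CSc1nc(-c2ccc(Cl)c(Cl)c2)c(C#N)c(=O)[nH]1`, has not yet been measured. It differs from compound 2 in one place: 3,4-dichlorophenyl in place of phenyl on an aromatic carbon. Going by the values given here, no measured pair shows this same change, so its size can only be judged from the spread of the three numbers. The two chlorine atoms recall compound 1, which carries a chlorophenyl on a different core and gives 44%, but that is a loose parallel. A modest step downward, a number 13.1 percentage points lower from compound 2 to compound 4 (beyond the scatter), is expected, not certainly beyond the scatter. Compound 4 is therefore expected to give 70%, within a range from 48% to 90%.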

Compound 4, a percentage reported as activity, at one concentration (the size of the read-out at that concentration, not a potency): 97.1%
Beside the measured number, compound 4's estimate is 27.1 percentage points below it, and the stated range ends below it.
By their numbers in this assay, from the lowest: compound 1; then compound 3; then compound 2; then compound 4.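

In this assay, putting 3,4-dichlorophenyl in place of phenyl on the aromatic carbon ortho to the cyano group gives a number 14 percentage points higher from compound 2 to compound 4 (beyond the scatter), so this change moves the compounds toward a weaker effect at the concentration tested. Going by these compounds alone, this is the first step read at this position, and it shows that the position responds to a change of its aryl group and that the added chlorine atoms do not strengthen the effect on this scaffold. Nothing measured here accounts for the step.

The compounds shown leave open whether one chlorine alone would produce the same step, or whether a hydroxyl group or an amine on this phenyl would move the number the other way. They also leave open whether the same replacement would act alike on the core of compound 1.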